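From 1-(methylamino)ethyl to pyrrolidin-2-yl on compound 1

A few compounds are considered here, and "the series" means these few. Any claim that something is new, unique, unknown or untested is made for them only; others in the source may bear on it.

Values measured in an in vivo ADME assay on the whole organism (strain Sprague-Dawley) for pharmacokinetics, with Rattus norvegicus as the target (on this read-out higher numbers stand for higher oral bioavailability and lower numbers for lower oral bioavailability), for three compounds:

- compound 1 `CN[C@@H](C)c1ccc(N2CC[C@H](NS(=O)(=O)c3ccc4cc(Cl)ccc4c3)C2=O)c(F)c1` gives > 10%
- compound 2 `CN(C)[C@@H]1CCc2cc(N3CC[C@H](NS(=O)(=O)c4ccc5cc(Cl)ccc5c4)C3=O)ccc21` gives 27%
- compound 3 `CNC1CCc2cc(N3CC[C@H](NS(=O)(=O)c4ccc5cc(Cl)ccc5c4)C3=O)ccc21` gives 25%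

Compound 1 has no number in this assay and stands only at a limit, > 10% as reported. This is the limit of > 10% in this assay, at which 1 of the 3 values shown sits, and it fixes no exact place for compound 1 among the others.

Compound 2 at 27% and compound 3 at 25% lie within the usual scatter of each other.

The account now turns to compound 4 `O=C1[C@@H](NS(=O)(=O)c2ccc3cc(Cl)ccc3c2)CCN1c1ccc(C2CCCN2)cc1F` which has not yet been measured. It differs from compound 1 by pyrrolidin-2-yl in place of 1-(methylamino)ethyl on an aromatic carbon, meta to a fluoro group pyrrolidin-2-yl in place of 1-(methylamino)ethyl on an aromatic carbon and the rest of the structure is shared.

For the measured compounds named here, no measured pair shows a change of this kind, so no shift beyond the usual scatter is expected, in either direction. The expected change is a step that the limit leaves unreadable from compound 1 to compound 4 as an estimate only.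

Compound 4 is expected at 18% with an estimated range from 8% to 35% in this assay when it is measured.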

Compound 4, oral bioavailability: 24%
Estimate against measurement, compound 4: 6 percentage points below; measured number inside the range.
By their numbers in this assay, from the lowest: compounds 4, 3 and 2 (each within the scatter of the next).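

The step from compound 1 to compound 4 cannot be read in this assay, because compound 1 stands only at a limit: the limit of > 10% in this assay, at which 1 of the 4 values shown sits.

The compounds shown leave open whether pyrrolidin-2-yl in place of 1-(methylamino)ethyl on an aromatic carbon shifts oral bioavailability at all, in either direction, in this assay.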